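Swapping Methoxy for Cyano on a Cytotoxicity Read-out

A few compounds are considered here, and "the series" means these few. Any claim that something is new, unique, unknown or untested is made for them only; others in the source may bear on it.

Of the compounds shown here, two have so far been measured in an ADME assay on Huh-7 cells (Homo sapiens) for cytotoxicity, read by MTT assay, with a stated time of 48 h; on this read-out lower numbers stand for higher toxicity in this test and higher numbers for lower toxicity in this test. Compound 1 `CN(C)CCCCOC(=O)Nc1ccc(Cn2nc(-c3cccc(C#N)c3)c3ccccc3c2=O)cc1` gives 17200 nM in this assay, and compound 2 `COc1ccccc1-c1nn(Cc2ccc(NC(=O)OCCCCN(C)C)cc2)c(=O)c2ccccc12` gives 44800 nM. For the measured compounds named here, compound 2 therefore stands at the higher of the two numbers, with compound 1 the only neighbour; the step of a 2.6-fold higher number from compound 1 to compound 2 (0.42 log units; beyond the scatter) shows how far apart they lie.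

Compound 3 `CN(C)CCCCOC(=O)Nc1ccc(Cn2nc(-c3ccccc3C#N)c3ccccc3c2=O)cc1` has not yet been measured. It differs from compound 2 in one place: cyano in place of methoxy on an aromatic carbon, ortho to a large group on a six-membered aromatic ring of carbon only. Going by the values given here, the one step that bears on this, a 2.6-fold higher number from compound 1 to compound 2 (0.42 log units; beyond the scatter), already moved from a cyano-bearing ring to a methoxy-bearing ring and raised the number modestly. Reversing that exchange, even at a different position on the ring, is expected to lower the number, so for compound 3 a step of a 2.0-fold lower number from compound 2 to compound 3 (0.31 log units; beyond the scatter) is estimated, giving an expected value of 22000 nM with a range from 9000 nM to 55000 nM.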

Compound 3, half-maximal cytotoxic concentration: 90700 nM
The estimate for compound 3 lay 4.1-fold (0.62 log units) below the measured number; the measured number lies above the stated range.
By their numbers in this assay, from the lowest: compound 1; then compound 2; then compound 3.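

In this assay, the step of a 2.0-fold higher number from compound 2 to compound 3 (0.31 log units; beyond the scatter) for cyano in place of methoxy shows that a cyano group on this ring does not by itself go with a lower number. Its place on the ring matters as well: 2-cyanophenyl in place of 3-cyanophenyl gives a 5.3-fold higher number from compound 1 to compound 3 (0.72 log units; beyond the scatter) with the same group on the same core. Compound 3 therefore has the highest number of the three and, by this read-out, the lowest toxicity in this test.

Nothing available explains why the number moves with the place of the cyano group. Also open, as far as these compounds go, is how a plain phenyl ring, or a 2-chlorophenyl or 2-aminophenyl ring, would compare on this core, and so whether 2-cyanophenyl stands out among other groups at this position.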